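A few compounds are considered here, and "the series" means these few. Any claim that something is new, unique, unknown or untested is made for them only; others in the source may bear on it.

Measured compounds:
- compound 1, `Clc1ccc2sc(CN3CCN(c4ncnc5c4CN(Cc4ccccc4)CC5)CC3)cc2c1`: 5%
- compound 2, `O=C(CN1CCN(c2ncnc3c2CN(Cc2ccccc2)CC3)CC1)Nc1cc(F)ccc1F`: 5%

In an assay on isolated protein for inhibition of tyrosine-protein kinase ZAP-70 (Homo sapiens), read by HTRF, tested at 10 uM (on this read-out higher numbers stand for more inhibition at the one concentration tested (going by the name of the read-out) and lower numbers for less inhibition), compound 1 gives 5%. Compound 2 gives 5% in the same test, so compound 1 stands level with compound 2 at the digits shown, and both show little inhibition at the single concentration tested. Within the data shown here, the only measured step, no change at the digits printed from compound 1 to compound 2 (within the scatter), swaps the group on the saturated chain carbon bound to the amine nitrogen in the ring, (2,5-difluorophenyl)carbamoyl in place of 5-chloro-1-benzothiophen-2-yl, and leaves the read-out unchanged within the scatter.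

Compound 3, `Cc1cc(C(=O)N2CCN(c3ncnc4c3CN(Cc3ccccc3)CC4)CC2)c(C)n1C`, has not yet been measured. It differs from compound 1 at the same ring nitrogen: (1,2,5-trimethyl-1H-pyrrol-3-yl)carbonyl in place of (5-chloro-1-benzothiophen-2-yl)methyl on an amine nitrogen in a ring

Among the measured compounds shown here, the one step that bears on this change, no change at the digits printed from compound 1 to compound 2 (within the scatter), shows that replacing the group on this ring nitrogen did nothing beyond the scatter. On that basis the step of no change at the digits printed from compound 1 to compound 3 (within the scatter) is expected to be small, with no clear direction. Compound 3 is therefore estimated at 5% in this assay, with a range from -8% to 22%.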

Compound 3, a percentage reported as inhibition, at one concentration (the size of the read-out at that concentration, not a potency): 0%
The estimate for compound 3 lay 5 percentage points above the measured number; measured number inside the range.
By their numbers in this assay, from the lowest: compounds 3, 1 and 2 (each within the scatter of the next).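

In this assay, a number 5 percentage points lower from compound 1 to compound 3 (within the scatter) shows that this amine nitrogen in a ring can carry a third kind of group without moving the read-out beyond the scatter. Compared with the earlier step, this change is of a different type: a carbonyl now sits directly on the ring nitrogen, and a single five-membered aromatic ring without sulfur or chlorine replaces the two-ring (5-chloro-1-benzothiophen-2-yl)methyl group. Compounds 1, 2 and 3 therefore remain within the scatter of one another despite these different groups, and the data offer no measured explanation for this flat result.

With all three compounds showing little inhibition at the one concentration tested, these results reveal no group at this nitrogen that raises the read-out, so they cannot show which parts of a group matter. Still open, going by these compounds, is whether a carboxylic acid on a longer chain, a primary amine on a longer chain, or a small acetyl group at this position would give a read-out beyond the scatter, and whether changing the shared core would do so.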